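Trimming the Side Chain of Compound 2

The source may hold more compounds than are shown below. What is called first, only, known or untested is meant among the compounds shown, and "the series" means these compounds.

Within the data shown here, in a functional assay on SAS cells (Homo sapiens) for cytotoxicity, read by MTT assay, with a stated time of 48 h (a higher number here means a weaker inhibitor, a lower number a stronger inhibitor), compound 1 `CC[C@H](C)[C@H](NC(=O)CSC1=C(OC)C(=O)c2ccccc2C1=O)C(=O)OC` gives 60000 nM and compound 2 `COC(=O)[C@H](CC(C)C)NC(=O)CSC1=C(OC)C(=O)c2ccccc2C1=O` gives 25500 nM (the lower of the two numbers so far). The next compound, compound 3 `COC(=O)[C@@H](NC(=O)CSC1=C(OC)C(=O)c2ccccc2C1=O)C(C)C`, has isopropyl in place of isobutyl on a saturated chain carbon bound to an amide-type nitrogen and a carbonyl carbon. Among the measured compounds shown here, only one measured step bears on this change, the swap of sec-butyl for isobutyl at the same place (a 2.4-fold lower number from compound 1 to compound 2 (0.37 log units; beyond the scatter)). It was modest but beyond the scatter, so this side chain can shift the number. For the measured compounds named here, no isopropyl compound has been measured, which leaves the direction uncertain. Compound 2 carries isobutyl and sits at the low end with 25500 nM, so a small shift towards a higher number is expected in this assay. The estimated step is a 1.6-fold higher number from compound 2 to compound 3 (0.22 log units; within the scatter) and is expected to be no larger than the measured one. For compound 3 the estimated value is 42000 nM (range 18000 nM to 95000 nM).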

Compound 3, half-maximal inhibitory concentration: 56000 nM
Compound 3: middle estimate off by 1.3-fold (0.12 log units), on the low side; low and high end bracket the measured number.
By their numbers in this assay, from the lowest: compound 2; then compounds 3 and 1 (each within the scatter of the next).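

In this assay the new change gives a 2.2-fold higher number from compound 2 to compound 3 (0.34 log units; beyond the scatter), so both swaps away from isobutyl at this position now raise the number beyond the scatter. Isopropyl and sec-butyl, by contrast, cannot be told apart here: the hydrogen in place of methyl that separates them gives a 1.1-fold lower number from compound 1 to compound 3 (0.03 log units; within the scatter), which means that the extra methyl alone makes no visible difference between these two side chains. Compound 2 therefore remains the strongest of the three, but nothing available explains why isobutyl stands apart.

As far as these compounds go, these three compounds carry only small hydrocarbon side chains, so it remains open whether a longer chain, a benzyl group or a chain ending in an amine would lower the number further. From the compounds shown here alone, it is also open how a carboxylic acid in place of the methyl ester would read.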